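A Double Bond in the Longest Chain

This account rests on a few compounds, and the source may have more. Where it says the series, first, only, none or still open, it means among the compounds named here.

Three amides sharing one core have been tested in an ADME assay on cells (Fibroblast, Homo sapiens) for antiproliferative activity, read by sulforhodamine B assay, with a stated time of 48 h; on this read-out lower numbers stand for stronger inhibition and higher numbers for weaker inhibition. Compound 1 `CCCCCCCCCCCCNC(=O)[C@@H]1CSC(c2ccc(NC(C)=O)cc2)N1` gives 3500 nM, and compound 2 `CCCCCCCCCCCCCCCCCNC(=O)[C@@H]1CSC(c2ccc(NC(C)=O)cc2)N1`, which has a longer chain, gives 35800 nM. Compound 3 `CCCCCCCCCCCCCCCCCCNC(=O)[C@@H]1CSC(c2ccc(NC(C)=O)cc2)N1` gives > 60000 nM, which is a limit of the assay and not a number. Compound 3 is thus the only one of the three without a measured value.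

Compound 4 `CCCCCCCCC/C=C/CCCCCCCNC(=O)[C@@H]1CSC(c2ccc(NC(C)=O)cc2)N1` differs from compound 3 by a single change: a group of 11 heavy atoms (11 carbon; no ring) in place of a group of 11 heavy atoms (11 carbon; no ring), on a saturated chain carbon, seven bonds along the chain from an amide-type nitrogen. Undecyl leaves, and the group that enters holds 1 double bond outside aromatic rings.

The measured steps that bear on this all lengthen the chain. Two are large: a 10-fold higher number from compound 1 to compound 2 (1.01 log units; beyond the scatter) and an at least 17-fold higher number from compound 1 to compound 3 (1.23 log units; beyond the scatter). The third, an at least 1.6-fold higher number from compound 2 to compound 3 (0.22 log units; that floor lies within the scatter), has a floor within the usual scatter. None of them tests a double bond, so they can only place compound 4 among the long-chain compounds, and the nearest measured number is compound 2 at 35800 nM. A modest move towards lower numbers is expected, though a second limit would be no surprise. The expected change is an at least 2.1-fold lower number from compound 3 to compound 4 (0.33 log units; beyond the scatter). For compound 4 the estimated value is 28000 nM, with an expected range from 8000 nM to 60000 nM.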

Compound 4, half-maximal inhibitory concentration: 18000 nM
For compound 4 the middle estimate is 1.6-fold (0.19 log units) above the measured one; the measured number falls inside the stated range.
By their numbers in this assay, from the lowest: compound 1; then compounds 4 and 2 (each within the scatter of the next). At a limit, above all of these: compound 3.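

In this assay, swapping undecyl for a group of the same size that holds one double bond turns a limit into a measured number: an at least 3.3-fold lower number from compound 3 to compound 4 (0.52 log units; beyond the scatter). On these data alone, compound 3 gives > 60000 nM, which is a limit of the assay and not a number, so this step is only a floor and its true size stays unknown: the limit of > 60000 nM in this assay, at which 1 of the 4 values shown sits. Set against the two saturated chains with measured values, the unsaturated chain sits level with the longer one, a 2.0-fold lower number from compound 2 to compound 4 (0.30 log units; within the scatter), and remains weaker than the shortest one, a 5.1-fold higher number from compound 1 to compound 4 (0.71 log units; beyond the scatter), so the double bond keeps a long chain on the scale without restoring the level of the shortest chain.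

The compounds shown leave open whether this result depends on the double bond's geometry or its place, seven bonds along the chain from the amide nitrogen, or whether a double bond of the opposite geometry, one elsewhere in the chain, or a triple bond would do the same. They also leave open whether a terminal amine or carboxylic acid on a chain of this length would move the number further.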